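Replacing the piperidine amide in compound 2

The source may report more compounds than this note shows. Statements on the series, on what has been measured and on what is new or still open speak of the compounds shown alone.

The three measured compounds share the core shown in compound 2 `CC1CCCN(C(=O)CN2CN(c3ccccc3)C3(CCN(C(=O)c4ccc(C5CCCCC5)cc4)CC3)C2=O)C1` and differ at the amide end and at the aromatic substituent. In an assay on HEK293 cells for displacement of a labelled ligand from NPC1-like intracellular cholesterol transporter 1 (Homo sapiens) (on this read-out higher numbers stand for weaker inhibition and lower numbers for stronger inhibition), compound 2 gives 3600 nM, the lowest of the three numbers. Compound 1 `CC(C)(C)OC(=O)NCC1CCCN(C(=O)CN2CN(c3ccccc3)C3(CCN(C(=O)c4ccc(C5CCCCC5)cc4)CC3)C2=O)C1` gives 3800 nM, and the step of a 1.1-fold lower number from compound 1 to compound 2 (0.02 log units; within the scatter) stays within the scatter. Compound 3 `CC1CCCN(C(=O)CN2CN(c3ccccc3)C3(CCN(C(=O)c4ccc(C(C)(C)C)cc4)CC3)C2=O)C1` gives 12000 nM, and the step of a 3.3-fold higher number from compound 2 to compound 3 (0.52 log units; beyond the scatter) lies beyond it.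

Compound 4 `O=C(CN1CN(c2ccccc2)C2(CCN(C(=O)c3ccc(C4CCCCC4)cc3)CC2)C1=O)NCO` is the next change from compound 2: (hydroxymethyl)amino in place of 3-methylpiperidin-1-yl on a carbonyl carbon. Within the data shown here, only the step from compound 1 to compound 2 touches the same region, and it stayed within the scatter, but it only stripped a substituent from the ring that compound 4 now loses altogether. The step from compound 2 to compound 3 concerns a different place and says nothing about this one. Among the measured compounds shown here, no measured pair tests the loss of the ring, so the direction is uncertain; a modest weakening is expected for compound 4, a 1.9-fold higher number from compound 2 to compound 4 (0.29 log units; within the scatter). The estimate for compound 4 is 7000 nM, expected to fall between 2000 nM and 25000 nM.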

Compound 4, half-maximal inhibitory concentration: 8300 nM
The estimate for compound 4 lay 1.2-fold (0.07 log units) below the measured number; measured number inside the range.
By their numbers in this assay, from the lowest: compounds 2 and 1 (each within the scatter of the next); then compounds 4 and 3 (each within the scatter of the next).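

Among these compounds, on the carbonyl carbon, (hydroxymethyl)amino in place of 3-methylpiperidin-1-yl gives a 2.3-fold higher number from compound 2 to compound 4 (0.36 log units; beyond the scatter), the first change at this end of the molecule to move the number beyond the scatter. Removing a substituent from the ring had not done so (a 1.1-fold lower number from compound 1 to compound 2 (0.02 log units; within the scatter)), whereas removing the ring itself does, though only modestly. Compound 4 still gives a measurable number without the ring, and no evidence here explains the shift.

This single step removes the ring and introduces the hydroxymethyl group together, so their separate contributions remain unresolved. Also open, on these data alone, is how piperidin-1-yl, dimethylamino, or a longer hydroxyalkyl chain on the amide nitrogen would read at this carbonyl carbon.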